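Second bromo on the fused ring: cytotoxicity outlook

The source may hold more compounds than are shown below. What is called first, only, known or untested is meant among the compounds shown, and "the series" means these compounds.

In an ADME assay on Vero cells (Chlorocebus sabaeus) for cytotoxicity, read by MTT assay, with a stated time of 72 h (on this read-out higher numbers stand for lower toxicity in this test and lower numbers for higher toxicity in this test), compound 1 `CNC1=C([N+](=O)[O-])C(c2ccc(N3CCN(c4ccnc5cc(Cl)ccc45)CC3)cc2)c2cc(Cl)ccc2O1` gives 74500 nM and compound 2 `CNC1=C([N+](=O)[O-])C(c2ccc(N3CCN(c4ccnc5cc(Cl)ccc45)CC3)cc2)c2cc(Br)ccc2O1` gives 88600 nM; the two values lie within the scatter of each other, and compound 2 sits alongside compound 1 with no separation beyond that scatter. Among the measured compounds shown here, the only measured step, a 1.2-fold higher number from compound 1 to compound 2 (0.08 log units; within the scatter), swaps one halogen for another at the same position and shows no effect beyond the scatter. Compound 3 `CNC1=C([N+](=O)[O-])C(c2ccc(N3CCN(c4ccnc5cc(Cl)ccc45)CC3)cc2)c2cc(Br)cc(Br)c2O1` differs from compound 2 by bromo in place of hydrogen on an aromatic carbon. For the measured compounds named here, no measured step covers the addition of a second halogen to the core, so the halogen swap from compound 1 to compound 2 is the only guide, and it bears on this step only loosely. The expected step of a 1.2-fold lower number from compound 2 to compound 3 (0.07 log units; within the scatter) is therefore small and within the scatter, with a slight lean toward a lower number. Compound 3 is expected at 75000 nM, within a range of 30000 nM to 190000 nM in this assay.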

Compound 3, half-maximal cytotoxic concentration: > 200000 nM
Compound 3: only a limit was reported (the forecaster's own chance of this, stated with the estimate: 5%); middle value at least 2.6-fold (0.42 log units) away from the limit.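

In this assay the addition of bromo in place of hydrogen on an aromatic carbon, ortho to a fused ring and meta to a bromo group, gives an at least 2.2-fold higher number from compound 2 to compound 3 (0.35 log units; beyond the scatter). Among the compounds shown here, the halogen swap, a 1.2-fold higher number from compound 1 to compound 2 (0.08 log units; within the scatter), left the read-out within the scatter, so this position gives the first change that lies beyond it, in the direction of lower toxicity in this test. The number for compound 3 is a limit and not a value, so the full size of the step stays unfixed: the limit of > 200000 nM in this assay, at which 1 of the 3 values shown sits.

Going by these compounds, whether the shift belongs to bromo itself or would also follow with chloro, a methoxy group or an amine at this position stays open. On these data alone, whether it depends on the bromo group already present on the ring also stays open.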